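The source may hold more compounds than are shown below. What is called first, only, known or untested is meant among the compounds shown, and "the series" means these compounds.

Measured so far:
Compound 1, `COc1ccc(-c2cc(/C=C/C(=O)c3ccc(OC)c(OC)c3)[nH]n2)cc1`: -77%
Compound 2, `COc1cc(-c2cc(/C=C/C(=O)c3ccc(Cl)c(Cl)c3)[nH]n2)cc(OC)c1OC`: -22%
Compound 3, `COc1ccc(-c2cc(/C=C/C(=O)c3ccc(N)cc3)[nH]n2)cc1`: -68%

All three were examined in a functional assay on OVCAR-4 cells (Homo sapiens) for cytotoxicity, read by sulforhodamine B assay, with a stated time of 48 h, tested at 100 uM; a higher number here means a weaker effect of the compound at the concentration tested, a lower number a stronger effect. Among them compound 2 stands highest, and its gaps to compound 3 and to compound 1 are both beyond the scatter, so compound 2 shows the weakest effect of the three in this assay. No two of these compounds differ in only one place, so no single measured step can be drawn between them.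

Compound 4, `COc1ccc(C(=O)/C=C/c2cc(-c3cc(OC)c(OC)c(OC)c3)n[nH]2)cc1OC`, has not yet been measured. It differs from compound 2 in one place: 3,4-dimethoxyphenyl in place of 3,4-dichlorophenyl on a carbonyl carbon. Compound 1 also carries a 3,4-dimethoxyphenyl on a carbonyl carbon, although compound 1 and compound 2 differ in more than one place, and compound 1 gives the lowest number of the three. On that basis a downward step, toward a stronger effect and beyond the scatter, is expected. Compound 4 is estimated at -60%, with a range from -85% to -25%. This amounts to an expected step of a number 38 percentage points lower from compound 2 to compound 4 (beyond the scatter).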

Compound 4, a percentage reported as activity, at one concentration (the size of the read-out at that concentration, not a potency): -82%
Compound 4: the middle estimate sits 22 percentage points above what was measured, within the range that was stated.
By their numbers in this assay, from the lowest: compounds 4, 1 and 3 (each within the scatter of the next, the first and the last beyond it); then compound 2.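

In this assay, among these compounds, 3,4-dimethoxyphenyl in place of 3,4-dichlorophenyl on a carbonyl carbon gives a number 60 percentage points lower from compound 2 to compound 4 (beyond the scatter) and is the first change in this set that can be read in one place. Among the compounds shown here, it shows that this group alone can carry a large difference in the read-out while the rest of compound 2 stays fixed, which the earlier compounds, all differing in more than one place, could not show. Nothing among the data shown accounts for the size of this step, and its cause remains unknown.

As far as these compounds go, it remains open whether a hydroxyl, an amine or a carboxylic acid on the same phenyl ring would give a number like that of compound 4, and whether both methoxy groups are needed. From the compounds shown here alone, it is also open whether the step would hold on the core of compound 1.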